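A few compounds are considered here, and "the series" means these few. Any claim that something is new, unique, unknown or untested is made for them only; others in the source may bear on it.

Compound 1 `CC(C)COc1ccccc1C1CC(=O)c2ccccc2O1`: 33200 nM
Compound 2 `C=CCOc1ccccc1C1CC(=O)c2ccccc2O1`: 38600 nM

Both measured compounds sit at the weak end of a functional assay on J774.A1 cells (Mus musculus) for inhibition, read by Griess assay, with stated times of 1 h and 24 h; on this read-out higher numbers stand for weaker inhibition and lower numbers for stronger inhibition. Compound 2 holds the higher of the two numbers, but its gap to compound 1 is within the scatter: a 1.2-fold higher number from compound 1 to compound 2 (0.07 log units; within the scatter), so the two are read as equivalent.

Compound 3 `COc1ccccc1C1CC(=O)c2ccccc2O1` is the next member. It differs from compound 2 in one place: hydrogen in place of vinyl on a saturated chain carbon bound to an oxygen on an aromatic ring. For the measured compounds named here, the only measured step that bears on this carbon is the one from compound 1 to compound 2, which stayed within the scatter, so exchange of the group on that carbon has so far left the number unchanged. Going by the values given here, removing the vinyl is a deeper cut than that exchange, and no measured step covers it, so the expectation is no step beyond the scatter, with a wide range. Compound 3 is expected to give 40000 nM (15000 nM to 110000 nM), a step of a 1.0-fold higher number from compound 2 to compound 3 (0.02 log units; within the scatter).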

Compound 3, half-maximal inhibitory concentration: 44500 nM
The estimate for compound 3 lay 1.1-fold (0.05 log units) below the measured number; low and high end bracket the measured number.
By their numbers in this assay, from the lowest: compounds 1, 2 and 3 (each within the scatter of the next).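

In this assay hydrogen in place of vinyl on a saturated chain carbon bound to an oxygen on an aromatic ring gives a 1.2-fold higher number from compound 2 to compound 3 (0.06 log units; within the scatter) and hydrogen in place of isopropyl on that same carbon gives a 1.3-fold higher number from compound 1 to compound 3 (0.13 log units; within the scatter) as the second step. Taking the group on this carbon away entirely, down to methoxy, therefore stays within the scatter, as exchanging it did, so the three compounds read as equivalent. At this carbon, neither the allyl nor the larger chain of compound 1 separates from methyl in this read-out. No supporting data bear on this result.

Still open, going by these compounds, is whether any group on this carbon moves the number beyond the scatter, for instance an amine, a carboxylic acid or a longer chain. The compounds shown also do not tell how a free hydroxyl in place of the methoxy would read, or how changes elsewhere on the shared core would read.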